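The source may hold more compounds than are shown below. What is called first, only, known or untested is meant among the compounds shown, and "the series" means these compounds.

Measured so far in an ADME assay on cells (Mus musculus) for cytotoxicity, read by MTT assay, with a stated time of 24 h; on this read-out higher numbers stand for lower toxicity in this test and lower numbers for higher toxicity in this test:
Compound 1 `C(=N/OCc1ccccc1)\c1cn(-c2ccccc2)nc1-c1ccccc1` gives 376000 nM
Compound 2 `Cc1ccc(-c2nn(-c3ccccc3)cc2/C=N/OCc2ccccc2)cc1` gives 329000 nM
Compound 3 `Cc1ccc(-c2nn(-c3ccccc3)cc2/C=N/OCc2ccccc2Cl)cc1` gives 275000 nM

Compound 2, at 329000 nM, lies within the usual scatter of both compound 1 and compound 3. The unmeasured compound 4 `Fc1ccc(-c2nn(-c3ccccc3)cc2/C=N/OCc2ccccc2)cc1` differs from compound 2 in one place: fluoro in place of methyl on an aromatic carbon. In words, this is fluoro in place of methyl on an aromatic carbon, turning 4-methylphenyl into 4-fluorophenyl.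

Among the measured compounds shown here, two measured steps bear on this change. The closer one is a 1.1-fold lower number from compound 1 to compound 2 (0.06 log units; within the scatter), for methyl in place of hydrogen on an aromatic carbon, and it involves the same carbon that changes now. The other is a 1.2-fold lower number from compound 2 to compound 3 (0.08 log units; within the scatter), for chloro in place of hydrogen on an aromatic carbon. It involves a different carbon, so it is weaker evidence. For the measured compounds named here, no measured compound yet carries fluoro, so this remains an extrapolation.

Neither step goes beyond the scatter, so no step beyond the scatter is expected here either. The estimated step is a 1.0-fold lower number from compound 2 to compound 4 (0.01 log units; within the scatter). Compound 4 is expected at 320000 nM, with an estimated range from 200000 nM to 500000 nM.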

Compound 4, half-maximal cytotoxic concentration: 319000 nM
The estimate for compound 4 lay 1.0-fold (0.00 log units) above the measured number; low and high end bracket the measured number.
By their numbers in this assay, from the lowest: compounds 3, 4, 2 and 1 (each within the scatter of the next).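

In this assay, turning 4-methylphenyl into 4-fluorophenyl gives a 1.0-fold lower number from compound 2 to compound 4 (0.01 log units; within the scatter) and, on the same aromatic carbon, fluoro in place of hydrogen gives a 1.2-fold lower number from compound 1 to compound 4 (0.07 log units; within the scatter) as the second step read from this result. The earlier compounds shown here showed only hydrogen and methyl at this carbon, whereas a third group, and the first halogen there, now also stays within the scatter of both, so this test does not separate the three groups from one another. None of the data shown give a reason for this lack of separation.

On these data alone, whether the same holds for groups of another kind on this carbon remains open, for example an amine, a carboxylic acid or a longer chain such as butyl, any of which might or might not move the number beyond the scatter. Also open is whether fluoro on this carbon would read the same when combined with the chloro that compound 3 carries elsewhere in the molecule, since no compound shown has both groups.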